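The source may report more compounds than this note shows. Statements on the series, on what has been measured and on what is new or still open speak of the compounds shown alone.

Compound 1 `COc1ccc(-n2ccc(=O)c(C(=O)Nc3ccc(Oc4ccnc5[nH]ccc45)c(F)c3)n2)cc1` gives 55400 nM in a functional assay on MCF7 cells (Homo sapiens) for cytotoxicity, read by MTT assay, with a stated time of 72 h; a higher number here means a weaker inhibitor, a lower number a stronger inhibitor. Compound 2 `Cn1ccc2c(Oc3ccc(NC(=O)c4nn(-c5ccc(Cl)cc5)ccc4=O)cc3)ccnc21` reaches only a limit, > 60000 nM. Compound 3 `COc1ccc(-n2ccc(=O)c(C(=O)Nc3ccc(Oc4ccnc5c4ccn5C)cc3)n2)cc1` likewise reaches only a limit, > 60000 nM.

Compound 3 therefore stands at the limit of > 60000 nM in this assay, at which 2 of the 3 values shown sit, and no number for it is known. Compound 4 `COc1ccc(-n2ccc(=O)c(C(=O)Nc3ccc(Oc4ccnc5c4ccn5C)c(F)c3)n2)cc1` carries fluoro in place of hydrogen on an aromatic carbon. Among the compounds with values here, the single measured step, a step that the two limits leave unreadable from compound 2 to compound 3, concerns another position and cannot be read in size, so no measured step bears on adding fluoro. Within the data shown here, compound 1 carries the same fluoro on a different core and gives 55400 nM, but no step connects it to compound 3. Compound 4 is expected near the limit again, at 60000 nM within 30000 nM to 120000 nM, a step of a number no higher from compound 3 to compound 4 (the limit leaves the size open) expected to stay within the scatter.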

Compound 4, half-maximal inhibitory concentration: > 60000 nM
Compound 4: only a limit was reported; the forecaster's own chance of this, stated with the estimate: 60%; the middle value lies on the limit itself.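

Compound 4 also reaches only a limit in this assay, so the step for adding fluoro to compound 3 cannot be read, and this position still has no measured size of change: the limit of > 60000 nM in this assay, at which 3 of the 4 values shown sit.

With the fluoro kept, methyl in place of hydrogen on the aromatic nitrogen gives an at least 1.0-fold higher number from compound 1 to compound 4 (0.03 log units; that floor lies within the scatter), so any real effect of that methyl remains unsized.

As far as these compounds go, it remains open how far compound 3 and compound 4 lie beyond the limit. From the compounds shown here alone, it is also open whether an amine or a carboxylic acid in place of the fluoro would give a readable value.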